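Permeability of a shared core: from compound 2 to compound 3

The source may report more compounds than this note shows. Statements on the series, on what has been measured and on what is new or still open speak of the compounds shown alone.

Compound 1, `CNC(=O)c1cc(Oc2ccc3nc(Nc4ccccc4)ncc3c2)ccn1`: < 1 10^-6 cm/s, a limit of the assay.
Compound 2, `CCc1ccccc1Nc1ncc2cc(Oc3ccnc(C(=O)NC)c3)ccc2n1`: < 1 10^-6 cm/s, a limit of the assay.

In an ADME assay on Caco-2 cells (Homo sapiens) for permeability, in the apical to basolateral direction (a higher number here means that the compound crosses the layer faster, a lower number that the compound crosses the layer more slowly), compound 1 gives < 1 10^-6 cm/s, which is a limit rather than a number. Compound 2 gives < 1 10^-6 cm/s in this assay, again a limit. The step that the two limits leave unreadable from compound 1 to compound 2 is thus unreadable, and the limit of < 1 10^-6 cm/s in this assay, at which 2 of the 2 values shown sit, is all that the two values show. Compound 3, `CNC(=O)c1cc(Oc2ccc3nc(Nc4ccc(OC(F)(F)F)cc4)ncc3c2)ccn1`, differs from compound 2 by 4-(trifluoromethoxy)phenyl in place of 2-ethylphenyl on a nitrogen on an aromatic ring. Going by the values given here, no measured step speaks readably to this change. Compound 3 is expected to stay near the same limit, with the step that the limit leaves unreadable from compound 2 to compound 3 expected to be small. Compound 3 is estimated at 0.7 10^-6 cm/s, in a range from 0.2 10^-6 cm/s to 2.5 10^-6 cm/s.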

Compound 3, apparent permeability: < 1 10^-6 cm/s
Compound 3 ended at the assay's limit; the forecaster's own chance of this, stated with the estimate: 65%; the middle value is on the limit's open side.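

Going by these compounds alone, compound 3 also gives a limit, as do compound 1 and compound 2, and no step among them can be read in this assay: the limit of < 1 10^-6 cm/s in this assay, at which 3 of the 3 values shown sit. Where the three compounds actually lie behind that limit, and whether any change between them shifts the read-out, stays open.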